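The source may report more compounds than this note shows. Statements on the series, on what has been measured and on what is new or still open speak of the compounds shown alone.

Compound 1 `CC(C)[C@H](NC(=O)COc1cccc2ccccc12)C(=O)N[C@@H](CC(=O)O)C(=O)CSc1nc(-c2ccccc2)cs1` is the reference of the series. In a functional assay on Jurkat cells (Homo sapiens) for inhibition (a higher number here means a weaker inhibitor, a lower number a stronger inhibitor), compound 1 gives > 200000 nM, which is a limit of the assay and not a number, so compound 1 stands only at a limit among the values shown. Compound 2 `CC(C)[C@H](NC(=O)COc1cccc2ccccc12)C(=O)N[C@@H](CC(=O)O)C(=O)CSc1nnnn1-c1ccccc1` gives 153000 nM in this assay. Compound 3 `CC(C)[C@H](NC(=O)COc1cccc2ccccc12)C(=O)N[C@@H](CC(=O)O)C(=O)CSc1nc2ccccc2s1` gives > 200000 nM in this assay, again a limit of the assay. The measured steps are an at least 1.3-fold lower number from compound 1 to compound 2 (0.11 log units; that floor lies within the scatter), an at least 1.3-fold higher number from compound 2 to compound 3 (0.11 log units; that floor lies within the scatter) and a step that the two limits leave unreadable from compound 1 to compound 3, with two of three values at the limit of > 200000 nM in this assay, at which 2 of the 3 values shown sit. Compound 4 `Cc1cc(OCC(=O)[C@H](CC(=O)O)NC(=O)[C@@H](NC(=O)COc2cccc3ccccc23)C(C)C)nc(C)n1` carries (2,6-dimethylpyrimidin-4-yl)oxy in place of (4-phenyl-1,3-thiazol-2-yl)sulfanyl on a saturated chain carbon bound to a carbonyl carbon. Going by the values given here, none of the measured steps changes the group on a sulfur in this way, so they bear on the step only by showing the series sitting near the limit. Compound 4 is therefore expected at 150000 nM, within 40000 nM to 500000 nM, an estimated step of an at least 1.3-fold lower number from compound 1 to compound 4 (0.12 log units; that floor lies within the scatter).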

Compound 4, half-maximal inhibitory concentration: > 200000 nM
Compound 4: only a limit was reported; the forecaster's own chance of this, stated with the estimate: 50%; middle value at least 1.3-fold (0.12 log units) away from the limit.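

In this assay compound 4 gives > 200000 nM, which is a limit of the assay. An oxygen-linked pyrimidine, (2,6-dimethylpyrimidin-4-yl)oxy, on a saturated chain carbon bound to a carbonyl carbon therefore does not bring the series clear of that limit, any more than the sulfur-linked thiazole of compound 1 does: the limit of > 200000 nM in this assay, at which 3 of the 4 values shown sit. Going by these compounds alone, the only readable new step is an at least 1.3-fold higher number from compound 2 to compound 4 (0.11 log units; that floor lies within the scatter), and the steps to compound 4 from the two other compounds at the limit cannot be read.

Going by these compounds, whether an amine at this place would give a value clear of the limit stays open. So does how far compound 1, compound 3 and compound 4 lie from one another.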